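The source may hold more compounds than are shown below. What is called first, only, known or untested is meant among the compounds shown, and "the series" means these compounds.

Measured compounds in a functional assay on HeLa cells (Homo sapiens) for cytotoxicity, read by MTT assay; a lower number here means a stronger inhibitor, a higher number a weaker inhibitor:

Compound 1, `CC1=NNC(=O)C1C(c1c(-c2ccccc2)[nH]c2ccc(C)cc12)c1c(-c2ccccc2)[nH]c2ccc(Cl)cc12` — compound 1 gives > 100000 nM, which is a limit of the assay rather than a number.
Compound 2, `CC1=NNC(=O)C1C(c1c(-c2ccccc2)[nH]c2ccccc12)c1c(-c2ccccc2)[nH]c2ccc(C)cc12` — compound 2 gives > 100000 nM, again a limit of the assay and not a number.

Compound 2 therefore stands nowhere above the floor of what this assay can report; both values shown sit at the same limit (the limit of > 100000 nM in this assay, at which 2 of the 2 values shown sit). Within the data shown here, the only measured step, a step that the two limits leave unreadable from compound 1 to compound 2, runs from one limit to another, so its size cannot be read.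

Compound 3, `CC1=NNC(=O)C1C(c1c[nH]c2ccccc12)c1c(-c2ccccc2)[nH]c2ccc(C)cc12`, differs from compound 2 by hydrogen in place of phenyl on an aromatic carbon. Among the measured compounds shown here, no measured step concerns the loss of a phenyl; the single step that exists, hydrogen for chloro, is unreadable and gives no direction. With both measured compounds at the limit, nothing in the numbers points to a gain in potency from this change.

Compound 3 is expected to stay at or near the limit, with an estimated value of 150000 nM (range 30000 nM to 500000 nM). The step this implies, a step that the limit leaves unreadable from compound 2 to compound 3, is expected to be no change beyond the scatter.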

Compound 3, half-maximal inhibitory concentration: 2400 nM
Beside the measured number, compound 3's estimate is 63-fold (1.80 log units) above it; the measured number lies below the stated range.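

In this assay hydrogen in place of phenyl on this aromatic carbon, next to the ring nitrogen, gives an at least 41-fold lower number from compound 2 to compound 3 (1.61 log units; beyond the scatter) and provides the only readable step among the compounds shown, since the step between the two earlier limits cannot be read. The result shows that this position can move the series off the limit, and that for this pair, keeping the phenyl goes with the weaker result and losing it with the stronger one. The size of the step is a lower bound only, because compound 2 carries a limit and not a number: the limit of > 100000 nM in this assay, at which 2 of the 3 values shown sit.

The compounds shown leave open whether a small group at this carbon, such as methyl or an amine, keeps the number of compound 3 or returns it to the limit, so the effect cannot yet be tied to the size or the nature of the group. They also leave open whether hydrogen in place of the phenyl that compound 3 retains on its other half, or a chloro on the core of compound 3, would shift the number further.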